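Chloro-azine carboxamides against nuclear factor kappa-B activation

The compounds below may be only part of what the source reports. "The series", "measured", "known", "first", "only" and "open" are said of these compounds alone.

Measured so far in an assay on Jurkat cells for activation of nuclear factor NF-kappa-B complex (Homo sapiens); a higher number here means a weaker inhibitor, a lower number a stronger inhibitor:
compound 1 `Cc1cc(C(=O)Nc2cc(C(F)(F)F)cc(C(F)(F)F)c2)nc(Cl)n1`: > 10000 nM, a limit of the assay rather than a number.
compound 2 `Cc1nc(Cl)ncc1C(=O)Nc1cc(C(F)(F)F)cc(C(F)(F)F)c1`: 50 nM.

Going by the values given here, compound 2 holds the only number in this assay; the value of compound 1 is a limit, as the limit of > 10000 nM in this assay, at which 1 of the 2 values shown sits, records. Among the compounds with values here, the single step between the two, an at least 200-fold lower number from compound 1 to compound 2 (2.30 log units; beyond the scatter), exchanges the heteroaryl group on the carbonyl carbon and is large. Compound 3 `O=C(Nc1cc(C(F)(F)F)cc(C(F)(F)F)c1)c1cnc(Cl)cn1` is not yet measured. It differs from compound 2 in one place: 5-chloropyrazin-2-yl in place of 2-chloro-4-methylpyrimidin-5-yl on a carbonyl carbon. Within the data shown here, the only measured step that bears on this change is an at least 200-fold lower number from compound 1 to compound 2 (2.30 log units; beyond the scatter), which likewise swapped one chloro-azine for another on the carbonyl carbon and was large. With a third ring now entering and the methyl leaving, one step does not fix the direction; the exchange is expected to cost some activity, a moderate step of a 10-fold higher number from compound 2 to compound 3 (1.00 log units; beyond the scatter) towards a higher number. Compound 3 is therefore estimated to give about 500 nM in this assay, within a range of 100 nM to 5000 nM.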

Compound 3, half-maximal inhibitory concentration: 4000 nM
Compound 3: the middle estimate sits 8.0-fold (0.90 log units) below what was measured; the range from low to high includes it.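

In this assay, a second exchange of the heteroaryl group on the carbonyl carbon also produces a large step: 5-chloropyrazin-2-yl in place of 2-chloro-4-methylpyrimidin-5-yl gives an 80-fold higher number from compound 2 to compound 3 (1.90 log units; beyond the scatter). In place of 2-chloro-6-methylpyrimidin-4-yl, the same group gives an at least 2.5-fold lower number from compound 1 to compound 3 (0.39 log units; beyond the scatter), so the three chloro-azines now fall into an order at this place, with compound 2 ahead of compound 3 and compound 3 ahead of compound 1. The value of compound 1 remains a limit and not a number, so the full size of the steps from it stays unknown: the limit of > 10000 nM in this assay, at which 1 of the 3 values shown sits.

Compound 2 and compound 3 differ both in the methyl group and in the arrangement of the ring nitrogens, and the compounds shown do not separate these two contributions to the step. Also open, going by these compounds, is whether an amine or a methoxy group in place of the chlorine, or a carboxylic acid on the azine ring, would keep the activity of compound 2.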